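The source may hold more compounds than are shown below. What is called first, only, known or untested is meant among the compounds shown, and "the series" means these compounds.

Compound 2 `CS(=O)(=O)Nc1ccc(NC(=O)Nc2cccc(-c3nc(-c4ccc(NC(=O)c5cccnc5)cc4Cl)no3)c2)cc1Br` holds the lowest number of the two measured in a functional assay on MDA-MB-231 cells (Homo sapiens) for antiproliferative activity, read by MTT assay, with a stated time of 72 h; on this read-out lower numbers stand for stronger inhibition and higher numbers for weaker inhibition; compound 2 gives 700 nM, while compound 1 `COc1ccc(NC(=O)Nc2cccc(-c3nc(-c4ccc(NC(=O)c5cccnc5)cc4Cl)no3)c2)cc1` gives 3000 nM in this assay. Compound 3 `CC(=O)Nc1ccc(NC(=O)Nc2cccc(-c3nc(-c4ccc(NC(=O)c5cccnc5)cc4Cl)no3)c2)cc1` carries 4-acetamidophenyl in place of 3-bromo-4-(methanesulfonamido)phenyl on an amide-type nitrogen. Among the measured compounds shown here, the one step that bears on this terminal aryl is a 4.3-fold lower number from compound 1 to compound 2 (0.63 log units; beyond the scatter), a modest change from the methoxyphenyl to the bromo-methanesulfonamidophenyl. The acetamidophenyl shares the hydrogen-bond donor counted above but lacks the bromine and sulfur, so compound 3 is expected to sit between the two measured compounds, a mild rise a 2.1-fold higher number from compound 2 to compound 3 (0.33 log units; beyond the scatter). Compound 3 is estimated at 1500 nM, range 600 nM to 4000 nM.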

Compound 3, half-maximal inhibitory concentration: > 10000 nM
Compound 3: no number, only a limit (the forecaster's own chance of this, stated with the estimate: 5%); middle value at least 6.6-fold (0.82 log units) from the limit.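

Compound 3 stands only as a limit of the assay, not as a number: the limit of > 10000 nM in this assay, at which 1 of the 3 values shown sits.

This terminal aryl on the amide-type nitrogen tolerates less than the first step suggested, with an at least 14-fold higher number from compound 2 to compound 3 (1.15 log units; beyond the scatter) and, for acetamido in place of methoxy on an aromatic carbon, an at least 3.3-fold higher number from compound 1 to compound 3 (0.52 log units; beyond the scatter). The leaving and entering groups in compound 2 and compound 3 each count one hydrogen-bond donor, so that count alone does not follow the read-out in this pair.

Compound 2 and compound 3 differ in the bromine and the sulfonamide at once, leaving the share of each open. From the compounds shown here alone, how a free amine or a carboxylic acid on this aryl would read also stays open.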